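Methoxyphenyl amide of the shared core: binding expectation

This account rests on a few compounds, and the source may have more. Where it says the series, first, only, none or still open, it means among the compounds named here.

Measured compounds and their values:
compound 1, `Cc1ccc(S(=O)(=O)NCc2ccc(CNC(=O)c3ccncc3)cc2)cc1`: 10 nM
compound 2, `Cc1ccc(S(=O)(=O)NCc2ccc(CNC(=O)c3c(Cl)cc(Cl)cc3Cl)cc2)cc1`: 10 nM
compound 3, `Cc1ccc(S(=O)(=O)NCc2ccc(CNC(=O)c3ccccc3)cc2)cc1`: > 1000 nM

In an assay on MDA-MB-231 cells for binding affinity to C-X-C chemokine receptor type 4 (Homo sapiens), read by immunofluorescence and microscopy, with stated times of 10 min and 30 min (a lower number here means that less compound is needed, a higher number that more compound is needed for the effect), compound 1 gives 10 nM. Compound 2 gives 10 nM, and the step of no change at the digits printed from compound 1 to compound 2 (within the scatter) shows that these two sit level within the scatter. Compound 3 is a different case: its value is only a limit, (the limit of > 1000 nM in this assay, at which 1 of the 3 values shown sits), so no number is known for it. Still, the steps of an at least 100-fold higher number from compound 1 to compound 3 (2.00 log units; beyond the scatter) and an at least 100-fold higher number from compound 2 to compound 3 (2.00 log units; beyond the scatter) are large, so the plain phenyl on the carbonyl carbon loses much of what pyridin-4-yl and 2,4,6-trichlorophenyl keep.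

Compound 4, `COc1ccccc1C(=O)NCc1ccc(CNS(=O)(=O)c2ccc(C)cc2)cc1`, has not been measured. It differs from compound 1 as follows: 2-methoxyphenyl in place of pyridin-4-yl on a carbonyl carbon. Both steps away from compound 1 bear on this change. A 2-methoxyphenyl is neither the bare phenyl of compound 3 nor the pyridin-4-yl of compound 1, so the outcome is uncertain: it could stay level with compound 1, as compound 2 did, or fall far, as compound 3 did. The estimated step is a 10-fold higher number from compound 1 to compound 4 (1.00 log units; beyond the scatter). Compound 4 is therefore expected to give about 100 nM in this assay, with a wide range from 8 nM to 1200 nM.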

Compound 4, effective concentration (reported as EC, without a stated level of effect): 100 nM
Beside the measured number, compound 4's estimate shows no gap at the digits printed; the range from low to high includes it.
By their numbers in this assay, from the lowest: compounds 1 and 2 (each within the scatter of the next); then compound 4. At a limit, above all of these: compound 3.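

Replacing hydrogen with methoxy on an aromatic carbon of the plain phenyl amide gives an at least 10-fold lower number from compound 3 to compound 4 (1.00 log units; beyond the scatter) in this assay, so a single small group on this ring is enough to separate compound 4 from compound 3. The reading for compound 3 in that step is only a limit: the limit of > 1000 nM in this assay, at which 1 of the 4 values shown sits. Even so, 2-methoxyphenyl does not match the other two groups on the carbonyl carbon, with a 10-fold higher number from compound 1 to compound 4 (1.00 log units; beyond the scatter) and a 10-fold higher number from compound 2 to compound 4 (1.00 log units; beyond the scatter), so this position now shows three levels of binding: pyridin-4-yl and 2,4,6-trichlorophenyl level with each other, 2-methoxyphenyl in the middle, and phenyl at the limit.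

Methoxy appears here only as 2-methoxyphenyl, so these compounds do not tell whether methoxy elsewhere on the ring would read the same, or whether a hydroxy group, a single chlorine or an amine in its place would give a similar gain over compound 3. They also leave open why two rings as different as pyridin-4-yl and 2,4,6-trichlorophenyl sit level, and the values alone give no reason for the order seen.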